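This account rests on a few compounds, and the source may have more. Where it says the series, first, only, none or still open, it means among the compounds named here.

Measured compounds:
compound 1 `Cc1c(Oc2ccccc2)ccc[n+]1[O-]` — 300 mg/kg
compound 2 `Cc1ccc(Oc2c[n+]([O-])ccc2C)cc1` — 300 mg/kg
compound 3 `[O-][n+]1ccc(CO)c(Oc2ccccc2)c1` — 300 mg/kg

In a functional assay on the whole organism with Mus musculus as the target, in the maximal electroshock model, with a stated time of 30 min (on this read-out higher numbers stand for an effect only at larger amounts of compound and lower numbers for an effect already at smaller amounts), compound 1 gives 300 mg/kg, compound 2 gives 300 mg/kg and compound 3 gives 300 mg/kg. Compound 3 stands level with compound 1 and compound 2 at the digits shown; its gaps to both lie within the scatter, so no order among the three can be stated. Compound 4 `[O-][n+]1ccc(C2CCCCC2)c(Oc2ccccc2)c1` is not yet measured in this assay. It differs from compound 3 in one place: cyclohexyl in place of hydroxymethyl on an aromatic carbon. Going by the values given here, no step between measured compounds bears on this change, and the three measured values give no direction to carry forward. The step of no change at the digits printed from compound 3 to compound 4 (within the scatter) is therefore expected to be none beyond the scatter. Compound 4 is expected to give 300 mg/kg, in the range 100 mg/kg to 1000 mg/kg.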

Compound 4, minimum effective dose: > 300 mg/kg
Compound 4 ended at the assay's limit; the forecaster's own chance of this, stated with the estimate: 30%; the middle value lies on the limit itself.
By their numbers in this assay, from the lowest: compounds 1, 2 and 3 (each within the scatter of the next).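

At the carbon opposite the ring nitrogen, cyclohexyl in place of hydroxymethyl gives, in this assay, a number no lower from compound 3 to compound 4 (the limit leaves the size open). For compound 4 the entry > 300 mg/kg is a limit of the assay and not a number. The change therefore brings no lowering of the minimum effective dose at this position, but its size stays unread, and the series now reaches the end of the tested range: the limit of > 300 mg/kg in this assay, at which 1 of the 4 values shown sits.

On these data alone, whether any group at this carbon lowers the dose remains open. An amine, a carboxylic acid or a longer chain ending in hydroxyl could each test this.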